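The source may report more compounds than this note shows. Statements on the series, on what has been measured and on what is new or still open speak of the compounds shown alone.

Compound 2 `COc1nc(C)c(Nc2nc(Cl)cn([C@H](COC(=O)Nc3ccc(Cl)cc3Cl)C3CC3)c2=O)cc1C` carries a 2,4-dichlorophenyl group on an amide-type nitrogen. For the measured compounds named here, in an assay on frontal cortex for displacement of a labelled ligand from corticotropin-releasing factor receptor 1 (Rattus norvegicus), with a stated time of 2 h (a lower number here means a stronger inhibitor, a higher number a weaker inhibitor), compound 2 gives 1.7 nM, and its only measured neighbour, compound 1 `COc1nc(C)c(Nc2nc(Cl)cn([C@H](COC(=O)Nc3ccccc3)C3CC3)c2=O)cc1C`, gives 1.5 nM in this assay; these two numbers sit within the scatter of each other, so neither compound can be called stronger. Going by the values given here, the single measured step, a 1.1-fold higher number from compound 1 to compound 2 (0.05 log units; within the scatter), shows that exchanging the aromatic ring on this nitrogen left the number essentially unchanged.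

Compound 3 `COc1nc(C)c(Nc2nc(Cl)cn([C@H](COC(=O)Nc3cccc(C#N)c3)C3CC3)c2=O)cc1C` is the next variation: 3-cyanophenyl in place of 2,4-dichlorophenyl on an amide-type nitrogen. Among the compounds with values here, this change touches the same nitrogen as the one measured step and, like it, swaps one aromatic ring for another. Because a 1.1-fold higher number from compound 1 to compound 2 (0.05 log units; within the scatter) lies within the scatter, the expected step for compound 3 is a 1.1-fold higher number from compound 2 to compound 3 (0.02 log units; within the scatter) in this assay, with no change beyond the scatter. Compound 3 is therefore estimated to give 1.8 nM in this assay, within a range from 0.8 nM to 4 nM.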

Compound 3, half-maximal inhibitory concentration: 1.3 nM
Compound 3: middle estimate off by 1.4-fold (0.14 log units), on the high side; the range from low to high includes it.
By their numbers in this assay, from the lowest: compounds 3, 1 and 2 (each within the scatter of the next).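

The step of a 1.3-fold lower number from compound 2 to compound 3 (0.12 log units; within the scatter) in this assay shows that this place on the amide-type nitrogen also accepts 3-cyanophenyl, which, unlike 2,4-dichlorophenyl, has a triple bond and a hydrogen-bond acceptor and contains no chlorine, with the step staying within the scatter. Cyano in place of hydrogen on an aromatic carbon of the plain phenyl ring, a 1.2-fold lower number from compound 1 to compound 3 (0.06 log units; within the scatter), also stays within the scatter, so the ring can carry a nitrile as well as chlorines without a readable difference. No measured evidence is available to explain this insensitivity.

Open, on these data alone, is whether the same holds for a ring bearing a carboxylic acid or an amine. Also open, as far as these compounds go, is whether a longer chain in place of the aromatic ring would keep the number in this range.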